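Aryl replacement at the ether-bearing core of the series

The source may report more compounds than this note shows. Statements on the series, on what has been measured and on what is new or still open speak of the compounds shown alone.

Measured so far:
compound 1 `Cc1cccc(-c2ccccc2OCC2=NCCN2)n1`: 80%
compound 2 `c1ccc(-c2cnccn2)c(OCC2=NCCN2)c1`: 97%

In a functional assay with Alpha-1A adrenergic receptor (Homo sapiens) as the target, read by calcium flux (on this read-out lower numbers stand for smaller maximal responses and higher numbers for larger maximal responses), compound 1 gives 80%. In this assay compound 2 gives 97%. For the measured compounds named here, compound 2 stands highest of the two numbers measured, and the only neighbour, compound 1, lies lower by a gap that goes beyond the usual scatter of the measurement. Two points are not enough to read any trend from the aryl group on the shared core; they only show that both aryl groups tried so far give a sizeable maximal response.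

Compound 3 `c1ccc(-c2ccoc2)c(OCC2=NCCN2)c1` has not yet been measured in this assay. It differs from compound 2 in a single place: furan-3-yl in place of pyrazin-2-yl on an aromatic carbon. No comparable step between measured compounds exists in the series, so the expectation must rest on the two numbers shown. With compound 2 at 97% as the starting point, the step from compound 2 to compound 3 in this assay is expected to be modest and downward, a number 11 percentage points lower from compound 2 to compound 3 (beyond the scatter), and it may fall within the scatter. Compound 3 is estimated at 86% in this assay, with a range from 66% to 102%.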

Compound 3, largest response reached (reported as maximum), in percent of the reference or control that the assay uses: 104%
Estimate against measurement, compound 3: 18 percentage points below; measured number outside the range, above it.
By their numbers in this assay, from the lowest: compound 1; then compounds 2 and 3 (each within the scatter of the next).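

In this assay the exchange of pyrazin-2-yl for furan-3-yl gives a number 7 percentage points higher from compound 2 to compound 3 (within the scatter), so at this aromatic carbon, ortho to the group of 7 heavy atoms, the change has no effect that can be told from the scatter. A six-membered aromatic ring with 2 hetero atoms and a five-membered aromatic ring with 1 hetero atom therefore cannot be separated on maximal response, and the difference of one heavy atom and one hydrogen-bond acceptor between the two groups leaves no readable mark on this read-out. No measured evidence bears on this result.

Still open, from the compounds shown here alone, is whether this position keeps the same maximal response once the aromatic ring gives way to a non-aromatic group, such as morpholine, an aminomethyl group or a carboxylic acid. Also open, going by these compounds, is whether the attachment point of the furan ring matters, as a comparison of furan-2-yl with furan-3-yl on the shared core in this assay would show.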